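Mirror-image step in the dichlorophenyl urea pair

This account rests on a few compounds, and the source may have more. Where it says the series, first, only, none or still open, it means among the compounds named here.

Three ureas of the shared core have been run in an ADME assay on the whole organism with Oryza sativa as the target, tested at 0.1 uM; a lower number here means a stronger effect, a higher number a weaker effect of the compound at the concentration tested. Compound 1 `C[C@@H](NC(=O)Nc1cccc(Cl)c1)c1ccccc1` gives 97%, its mirror image compound 2 `C[C@H](NC(=O)Nc1cccc(Cl)c1)c1ccccc1` gives 103%, and compound 3 `C[C@@H](NC(=O)Nc1cc(Cl)cc(Cl)c1)c1ccccc1` gives 99%. Compound 3 sits with compound 1 and compound 2 inside the scatter of one another: a number 2 percentage points higher from compound 1 to compound 3 (within the scatter), and a number 6 percentage points higher from compound 1 to compound 2 (within the scatter).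

Compound 4 `C[C@H](NC(=O)Nc1cc(Cl)cc(Cl)c1)c1ccccc1` is the counterpart of compound 3: the two compounds have the same atoms and bonds and differ only in configuration as drawn: 1 of 1 stereo elements differ; a stereocentre at a saturated chain carbon is drawn R in compound 3 and S in compound 4. Within the data shown here, the one measured step of the same kind is that from compound 1 to compound 2, where the change rests solely on the fact that compounds 1 and 2 differ only in the configuration as drawn and gave a number 6 percentage points higher from compound 1 to compound 2 (within the scatter), within the scatter. The added chloro did not shift the read-out either, as a number 2 percentage points higher from compound 1 to compound 3 (within the scatter) shows.

No step beyond the scatter is therefore expected in this assay for compound 4; the estimated move is a number 4 percentage points higher from compound 3 to compound 4 (within the scatter). Compound 4 is expected to give about 103%, within a range of 92% to 114%.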

Compound 4, a percentage reported as activity, at one concentration (the size of the read-out at that concentration, not a potency): 99%
Compound 4: middle estimate off by 4 percentage points, on the high side, within the range that was stated.
By their numbers in this assay, from the lowest: compounds 1, 3, 4 and 2 (each within the scatter of the next).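

The mirror-image change at the saturated chain carbon can now be read on a second core in this assay, where the step is no change at the digits printed from compound 3 to compound 4 (within the scatter), so neither pair separates by configuration: the fact that compounds 3 and 4 differ only in the configuration as drawn

The chloro in place of hydrogen on an aromatic carbon can also now be read with the chain carbon drawn S, where the step is a number 4 percentage points lower from compound 2 to compound 4 (within the scatter), and it stays inside the scatter with either configuration: the same change on two cores in this assay, a number 2 percentage points higher (within the scatter) from compound 1 to compound 3 and a number 4 percentage points lower (within the scatter) from compound 2 to compound 4, 6 percentage points apart, within the scatter of two such steps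

Neither change therefore moves the read-out beyond the scatter in these four compounds.

No compound shown stands clear of the scatter, so it remains open which structural changes, if any, can move the read-out in this assay. As far as these compounds go, whether an amine, a carboxylic acid or a longer chain on the shared core would do so also stays open.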